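A few compounds are considered here, and "the series" means these few. Any claim that something is new, unique, unknown or untested is made for them only; others in the source may bear on it.

Compound 2 `COc1ccc(CN(C(=O)CSc2nncs2)c2cc(OC)c(OC)c(OC)c2)cc1` holds the lowest of the two numbers in a functional assay on MCF7 cells (Homo sapiens) for antiproliferative activity, read by MTT assay, with a stated time of 48 h; a lower number here means a stronger inhibitor, a higher number a weaker inhibitor: compound 2 gives 19400 nM, while compound 1 `COc1ccc(CN(C(=O)COc2ccc(OC)cc2)c2cc(OC)c(OC)c(OC)c2)cc1` gives 46400 nM. For the measured compounds named here, the single measured step, a 2.4-fold lower number from compound 1 to compound 2 (0.38 log units; beyond the scatter), is the only one that bears on the change to compound 3 `COc1ccc(CN(C(=O)COc2ccccc2)c2cc(OC)c(OC)c(OC)c2)cc1`, which is phenoxy in place of (1,3,4-thiadiazol-2-yl)sulfanyl on a saturated chain carbon bound to a carbonyl carbon. That step ran in the opposite sense on a closely related group, so a modest rise in number is expected for compound 3, roughly a 1.8-fold higher number from compound 2 to compound 3 (0.26 log units; within the scatter). Compound 3 is therefore estimated at 35000 nM, within 15000 nM to 80000 nM.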

Compound 3, half-maximal inhibitory concentration: 64100 nM
Compound 3: the middle estimate sits 1.8-fold (0.26 log units) below what was measured, and the stated range covers the measured number.
By their numbers in this assay, from the lowest: compound 2; then compounds 1 and 3 (each within the scatter of the next).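

In this assay, the (1,3,4-thiadiazol-2-yl)sulfanyl group now holds its lead over phenoxy as well as over 4-methoxyphenoxy, with a 3.3-fold higher number from compound 2 to compound 3 (0.52 log units; beyond the scatter). Hydrogen in place of methoxy on an aromatic carbon changes little, with a 1.4-fold higher number from compound 1 to compound 3 (0.14 log units; within the scatter), so the two oxygen-linked groups cannot be told apart here. Nothing available explains the gap to compound 2.

The compounds shown leave open whether the sulfur link or the five-membered aromatic ring carries the difference. From the compounds shown here alone, how an amine on the saturated chain carbon would read also remains open.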